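Acetoxy to hydroxy on the tetramethyl dioxolane series

The source may report more compounds than this note shows. Statements on the series, on what has been measured and on what is new or still open speak of the compounds shown alone.

Measured in a functional assay on A549 cells (Homo sapiens) for antiproliferative activity, read by sulforhodamine B assay, with a stated time of 72 h; on this read-out higher numbers stand for weaker inhibition and lower numbers for stronger inhibition:
- compound 1 `CC(=O)Oc1cc2c(CCC=C(C)C)c(C)ccc2cc1C(C)C` gives 25500 nM
- compound 2 `CC(=O)Oc1cc2c(CC[C@@H](O)C(C)(C)O)c(C)ccc2cc1C(C)C` gives 48600 nM
- compound 3 `CC(=O)Oc1cc2c(CC[C@H]3OC(C)(C)OC3(C)C)c(C)ccc2cc1C(C)C` gives 28900 nM

Compound 3 is not separated from the other two. The gaps are a 1.1-fold higher number from compound 1 to compound 3 (0.05 log units; within the scatter) and a 1.7-fold lower number from compound 2 to compound 3 (0.23 log units; within the scatter).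

Compound 4 `Cc1ccc2cc(C(C)C)c(O)cc2c1CC[C@H]1OC(C)(C)OC1(C)C` carries one change: hydrogen in place of acetyl on an oxygen on an aromatic ring. Among the compounds with values here, no measured step touches that oxygen. The available steps, those above and a 1.9-fold higher number from compound 1 to compound 2 (0.28 log units; within the scatter), all alter the saturated chain, so they bear only indirectly. With no guide for a direction, no shift beyond the scatter is expected in this assay. The estimated step is a 1.2-fold lower number from compound 3 to compound 4 (0.06 log units; within the scatter). For compound 4 the expected value is 25000 nM, with an estimated range of 9000 nM to 60000 nM.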

Compound 4, half-maximal inhibitory concentration: 23500 nM
Beside the measured number, compound 4's estimate is 1.1-fold (0.03 log units) above it; the measured number falls inside the stated range.
By their numbers in this assay, from the lowest: compounds 4, 1, 3 and 2 (each within the scatter of the next, the first and the last beyond it).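

In this assay, within the data shown here, hydrogen in place of acetyl on the oxygen on the aromatic ring gives a 1.2-fold lower number from compound 3 to compound 4 (0.09 log units; within the scatter), the first reading at this position. For this pair, acetoxy to hydroxy leaves the number within the scatter, so the acetyl is not needed to retain this level of antiproliferative activity. Nothing available explains this flat step. Open, going by these compounds, is whether a methoxy or an amine in place of the hydroxy would shift the number. Also open, on these data alone, is whether acetoxy to hydroxy reads the same with the 2-methylprop-1-en-1-yl of compound 1 or the 1,2-dihydroxy-2-methylpropyl of compound 2.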